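A few compounds are considered here, and "the series" means these few. Any claim that something is new, unique, unknown or untested is made for them only; others in the source may bear on it.

Working notes on the series.

Compound 1 `Nc1nc(O)c2c(n1)n(C1OC(CO)[C@@H](O)[C@H]1O)c(=O)n2C/C=C/c1ccccc1` is the reference here. Among the compounds with values here, in a functional assay (B cells) with Mus musculus as the target (a lower number here means that less compound is needed, a higher number that more compound is needed for the effect), compound 1 gives 103 uM, the second highest of the three numbers known so far. Compound 2 `C=CCn1c(=O)n(C2CCC(CO)C2)c2nc(N)nc(O)c21` gives 226 uM in this assay, a higher number than compound 1 and beyond the usual scatter. Compound 3 `C=CCn1c(=O)n(CCC(CCOCc2ccccc2)CCOCc2ccccc2)c2nc(N)nc(O)c21` gives 7 uM in this assay, a lower number than compound 1 and well beyond the scatter; this is the lowest number of the three. No pair among these three differs in a single place, so no clean step is available to anchor the next change.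

Compound 4 `Nc1nc(O)c2c(n1)n(C1OC(CO)[C@@H](O)[C@H]1O)c(=O)n2Cc1ccc(Cl)cc1` is not yet measured. It differs from compound 1 in one place: 4-chlorophenyl in place of 2-phenylethenyl on a saturated chain carbon bound to an aromatic nitrogen. Within the data shown here, no measured pair shows this change, so its size and direction are uncertain. Compound 4 is expected to stay near compound 1, with an estimated step of a 1.3-fold lower number from compound 1 to compound 4 (0.11 log units; within the scatter) and a wide range. For compound 4 the expected value in this assay is 80 uM, within 25 uM to 250 uM.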

Compound 4, concentration for half-maximal effect: 14 uM
Compound 4: the middle estimate sits 5.7-fold (0.76 log units) above what was measured; the whole stated range lies above it.
By their numbers in this assay, from the lowest: compounds 3 and 4 (each within the scatter of the next); then compound 1; then compound 2.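

In this assay, within the data shown here, the exchange of 2-phenylethenyl for 4-chlorophenyl on a saturated chain carbon bound to an aromatic nitrogen gives a 7.4-fold lower number from compound 1 to compound 4 (0.87 log units; beyond the scatter) and provides the first clean step. It shows that the number in this assay changes with the group at this position while the rest of compound 1 stays the same. No measured evidence bears on the reason for this step.

The change removes the double bond outside the aromatic ring and brings in chlorine together, so the step cannot be assigned to either alone; a plain benzyl group would separate the two, and a 4-bromobenzyl group or a longer chain such as 2-(4-chlorophenyl)ethyl would test the group further. As far as these compounds go, whether 4-chlorobenzyl gives a similar step on the other parts of compound 2 and compound 3 also stays open.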